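The source may hold more compounds than are shown below. What is called first, only, known or untested is meant among the compounds shown, and "the series" means these compounds.

Working notes on the series. Compound 1 `COc1cc(-c2nnc3n2NC(c2cccs2)C(C(=O)c2ccc(C)cc2)S3)cc(OC)c1OC`, compound 2 `COc1cc(-c2nnc3n2NC(c2ccco2)C(C(=O)C2CC2)S3)cc(OC)c1OC` and compound 3 `COc1cc(C(=O)C2Sc3nnc(-c4cc(OC)c(OC)c(OC)c4)n3NC2c2cccs2)cc(OC)c1OC` share one core and differ in the group on a carbonyl carbon and in a heteroaryl group. In a functional assay on A549 cells (Homo sapiens) for cytotoxicity, read by MTT assay, with a stated time of 48 h (on this read-out lower numbers stand for stronger inhibition and higher numbers for weaker inhibition), compound 1 gives 12700 nM. Compound 2 reaches only the limit of the assay, > 100000 nM, and not a number. Compound 3 likewise sits at the limit, > 100000 nM. Within the data shown here, the one measured step with a single change, an at least 7.8-fold higher number from compound 1 to compound 3 (0.89 log units; beyond the scatter), runs towards weaker inhibition; its size is bounded by the limit of > 100000 nM in this assay, at which 2 of the 3 values shown sit, so its true extent is open. Compound 2 thus stands at the weak end of what is shown, without a number of its own.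

Compound 4 `COc1cc(-c2nnc3n2NC(c2ccco2)C(C(=O)c2ccc(O)cc2)S3)cc(OC)c1OC` differs from compound 2 by 4-hydroxyphenyl in place of cyclopropyl on a carbonyl carbon. Among the measured compounds shown here, no measured step exchanges cyclopropyl for an aryl group on the carbonyl carbon; the only step at that carbon, an at least 7.8-fold higher number from compound 1 to compound 3 (0.89 log units; beyond the scatter), exchanges one aryl for another and shows that changes there move the number at least modestly. For the measured compounds named here, compound 4 carries an aryl ketone as compound 1 does, and compound 1 is the one compound here with a number, 12700 nM. The expectation for compound 4 is therefore a move towards stronger inhibition, an at least 2.5-fold lower number from compound 2 to compound 4 (0.39 log units; beyond the scatter), with a fair chance that the limit is reported again. Compound 4 is estimated at 40000 nM, within 10000 nM to 100000 nM.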

Compound 4, half-maximal inhibitory concentration: 93400 nM
For compound 4 the middle estimate is 2.3-fold (0.37 log units) below the measured one; measured number inside the range.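

In this assay, replacing cyclopropyl with 4-hydroxyphenyl on a carbonyl carbon gives an at least 1.0-fold lower number from compound 2 to compound 4 (0.02 log units; that floor lies within the scatter), the first step shown at this carbon that exchanges a saturated ring for an aromatic one. Going by these compounds, compound 4 gives a number where compound 2 gives only a limit, yet the size of the step stays unknown and may be no larger than the usual scatter, because the value of compound 2 is not a number: the limit of > 100000 nM in this assay, at which 2 of the 4 values shown sit. Compound 4, at 93400 nM, is measured only just inside the range of the assay, so in this pair the 4-hydroxyphenyl ketone brings no clear gain in this assay.

The compounds shown leave open whether the hydroxyl group contributes anything to this result, as no pair sets 4-hydroxyphenyl against a plain phenyl on the carbonyl carbon. Also open, on these data alone, is whether an amine or a carboxylic acid in place of that hydroxyl group, or the 4-methylphenyl of compound 1 combined with the heteroaryl group of compound 2, would move the number clearly away from the limit.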